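Removing a chloro from the pendant ring of a chalcone-type core

This account rests on a few compounds, and the source may have more. Where it says the series, first, only, none or still open, it means among the compounds named here.

Measured so far:
compound 1, `Cc1cc(O)c(C(=O)/C=C/c2ccccc2Cl)c(-c2ccc(Cl)cc2)c1C(=O)/C=C/c1ccccc1Cl` — 30000 nM
compound 2, `Cc1cc(O)c(C(=O)/C=C/c2ccc(Cl)cc2)c(-c2ccc(Cl)cc2)c1C(=O)/C=C/c1ccc(Cl)cc1` — 28000 nM

Both compounds were tested in a functional assay on MCF7 cells (Homo sapiens) for cytotoxicity, read by MTT assay, with a stated time of 24 h; a higher number here means a weaker inhibitor, a lower number a stronger inhibitor. Compound 1 gives 30000 nM, the higher of the two numbers, and compound 2 gives 28000 nM; the gap between them is within the scatter, so the two values cannot be told apart. Both compounds are weak in this assay.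

Compound 3, `Cc1cc(O)c(C(=O)/C=C/c2ccccc2Cl)c(-c2ccccc2)c1C(=O)/C=C/c1ccccc1Cl`, has not yet been measured. It differs from compound 1 by hydrogen in place of chloro on an aromatic carbon; seen one bond further out, a 4-chlorophenyl becomes a phenyl, and the place of the change is an aromatic carbon of a six-membered carbon ring, para to a large group. Among the compounds with values here, no measured pair in this set isolates this change, so its effect cannot be read from the data. Given that compound 1 and compound 2 sit together despite a change elsewhere, the expected step from compound 1 to compound 3 is a 1.2-fold higher number from compound 1 to compound 3 (0.07 log units; within the scatter), which is not beyond the scatter in either direction. Compound 3 is therefore estimated to give 35000 nM in this assay, with a range from 12000 nM to 100000 nM.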

Compound 3, half-maximal inhibitory concentration: "not active" (no number reported)
Compound 3: no number reported, so the estimate cannot be set against anything.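

In this assay, within the data shown here, compound 3 is reported as not active, without a number, so no step from compound 1 to compound 3 can be read. The compounds shown leave open how far the change from 4-chlorophenyl to phenyl shifts the value of compound 1 at 30000 nM in either direction. Nothing further on hand bears on this result.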